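A Fluorine Added to the Carbon Ring of Compound 1

A few compounds are considered here, and "the series" means these few. Any claim that something is new, unique, unknown or untested is made for them only; others in the source may bear on it.

Three compounds have been measured in an assay for inhibition of steroid 17-alpha-hydroxylase/17,20 lyase (Homo sapiens), using NADPH, tested at 0.2 uM; a higher number here means a stronger effect of the compound at the concentration tested, a lower number a weaker effect:
compound 1 `CCC(c1ccc(-c2cscc2C)cc1)n1ccnc1` gives 27%
compound 2 `Fc1ccc(-c2ccc(Cn3ccnc3)cc2)cn1` gives 4%
compound 3 `c1cncc(-c2ccc(Cn3ccnc3)cc2)c1` gives 2%

Compound 1 stands highest; its gaps to compound 2 and compound 3 lie beyond the scatter. How the core of compound 1 differs from that of compound 3 is not broken down here. Compound 2 and compound 3 differ by one change, (fluoro in place of hydrogen on an aromatic carbon), which gave a number 2 percentage points higher from compound 3 to compound 2 (within the scatter). Compound 4 `CCC(c1ccc(-c2cscc2C)cc1F)n1ccnc1` has not been measured; it differs from compound 1 by fluoro in place of hydrogen on an aromatic carbon. This is the same kind of change, not the same: in compound 2 the fluoro sits next to the ring nitrogen, para to a large group, whereas in compound 4 it sits ortho to a group of 8 heavy atoms, meta to a 4-methylthiophen-3-yl group. Resting on the small step of a number 2 percentage points higher from compound 3 to compound 2 (within the scatter), the step for compound 4 is expected to be a number 3 percentage points higher from compound 1 to compound 4 (within the scatter). Compound 4 is estimated at 30%, between 15% and 45%.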

Compound 4, a percentage reported as inhibition, at one concentration (the size of the read-out at that concentration, not a potency): 41%
Estimate against measurement, compound 4: 11 percentage points below; the range from low to high includes it.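

In this assay, fluoro in place of hydrogen on an aromatic carbon of the core of compound 1 gives a number 14 percentage points higher from compound 1 to compound 4 (beyond the scatter). This step cannot be told apart from the earlier step on the other core: the same change on two cores in this assay, a number 2 percentage points higher (within the scatter) from compound 3 to compound 2 and a number 14 percentage points higher (beyond the scatter) from compound 1 to compound 4, 12 percentage points apart, within the scatter of two such steps The two results are therefore compatible with the change carrying over between these cores, but two pairs cannot establish a rule, and the fluoro stands in a different place in each pair.

As far as these compounds go, whether a chloro or a methoxy group on the same carbon would match the fluoro remains open. From the compounds shown here alone, it is also open whether the step would hold on a core carrying an amine or a carboxylic acid.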